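From Compound 3 to Compound 4: Swapping One Chain

The source may report more compounds than this note shows. Statements on the series, on what has been measured and on what is new or still open speak of the compounds shown alone.

Three compounds with a shared core, differing in the group on the carbonyl carbon, have been tested in an ADME assay for pharmacokinetics, read by LC-MS, in phosphate buffer, with a stated time of 120 min, at pH 7.4, tested at 1 uM, in the presence of a further agent that is not named here; a lower number here means that the compound disappears faster, a higher number that the compound lasts longer. In this assay compound 1 (`C=C(Cl)C(=O)Nc1ccccc1`) has a half-life of 0.05 h.

Compound 2 (`C/C=C/C(=O)Nc1ccccc1`) gives > 8.53 h, which is a limit of the assay and not a number. Compound 3 (`O=C(/C=C/CF)Nc1ccccc1`) gives > 8.53 h, which is also a limit. Both therefore sit at the limit of > 8.53 h in this assay, at which 2 of the 3 values shown sit, and between them there is a step that the two limits leave unreadable from compound 2 to compound 3.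

Compound 4 (`C=C(C)C(=O)Nc1ccccc1`) has 1-methylethenyl in place of 3-fluoroprop-1-en-1-yl on a carbonyl carbon.

One large measured step removes 1-chloroethenyl: an at least 170-fold higher number from compound 1 to compound 2 (2.23 log units; beyond the scatter). Compound 4 also lacks 1-chloroethenyl, so it is expected to resemble the other large step, an at least 170-fold higher number from compound 1 to compound 3 (2.23 log units; beyond the scatter), and to stay close to compound 3.

No change beyond the scatter is therefore expected, and the estimated step is a step that the limit leaves unreadable from compound 3 to compound 4. For compound 4 the estimated half-life is 12 h, with an expected range from 5 h to 30 h.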

Compound 4, half-life: > 8.53 h
Compound 4: only a limit was reported (the forecaster's own chance of this, stated with the estimate: 75%); the middle value is on the limit's open side.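

In this assay, the change of methyl in place of chloro on a double-bonded chain carbon bound to a carbonyl carbon gives an at least 170-fold higher number from compound 1 to compound 4 (2.23 log units; beyond the scatter). The earlier large steps from compound 1 replaced the whole group on the carbonyl carbon, whereas this one alters a single substituent on that group. Compound 4 gives > 8.53 h, which is a limit of the assay and not a number. The steps among compound 2, compound 3 and compound 4 cannot be read, because all three stop at the same limit: the limit of > 8.53 h in this assay, at which 3 of the 4 values shown sit.

From the compounds shown here alone, how far beyond that limit compound 2, compound 3 and compound 4 lie stays open, and so does whether they differ at all. Also open, going by these compounds, is whether bromo or a longer chain on that same double-bonded chain carbon would behave like compound 1 or like compound 4.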